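The source may hold more compounds than are shown below. What is called first, only, known or untested is meant among the compounds shown, and "the series" means these compounds.

Measured in a functional assay on L1210 cells (Mus musculus) for inhibition, read by MTT assay, with a stated time of 72 h; on this read-out higher numbers stand for weaker inhibition and lower numbers for stronger inhibition:
- compound 1 `COc1cc(NC(C)CCCNC(=O)NNC(=O)Nc2ccc(Cl)cc2)c2ncccc2c1`: 58000 nM
- compound 2 `COc1cc(NC(C)CCCNC(=O)NNC(=O)Nc2ccc(C(F)(F)F)cc2)c2ncccc2c1`: 18000 nM
- compound 3 `COc1cc(NC(C)CCCNC(=O)Nc2cc(C(F)(F)F)cc(C(F)(F)F)c2)c2ncccc2c1`: 3500 nM

Not yet measured: compound 4 `COc1cc(NC(C)CCCNC(=O)Nc2ccc(C(F)(F)F)cc2)c2ncccc2c1`.

Compound 1 has the highest number of the three. The step under review is 4-(trifluoromethyl)phenyl in place of ((4-chlorophenyl)carbamoyl)amino on an amide-type nitrogen, which puts 4-(trifluoromethyl)phenyl in place of ((4-chlorophenyl)carbamoyl)amino on an amide-type nitrogen.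

Among the compounds with values here, only one measured step bears directly on part of this change: a 3.2-fold lower number from compound 1 to compound 2 (0.51 log units; beyond the scatter). It is modest but beyond the scatter, and it swaps chloro for trifluoromethyl on an aromatic carbon. Within the data shown here, the loss of the carbamoyl-amino portion has no measured step of its own. The nearest guide is compound 3, which also has its aromatic ring directly on that nitrogen but carries a second trifluoromethyl group. In this assay compound 3 gives 3500 nM. Among the measured compounds shown here, no measured pair separates these two contributions, so the estimate is uncertain.

A lower number than for compound 1 is expected in this assay, by more than the measured chloro-to-trifluoromethyl step and beyond the scatter. The expected overall change is a 9.7-fold lower number from compound 1 to compound 4 (0.99 log units; beyond the scatter). For compound 4 the estimated value is 6000 nM. The estimated range for compound 4 runs from 2500 nM to 15000 nM.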

Compound 4, half-maximal inhibitory concentration: 7400 nM
For compound 4 the middle estimate is 1.2-fold (0.09 log units) below the measured one; measured number inside the range.
By their numbers in this assay, from the lowest: compound 3; then compound 4; then compound 2; then compound 1.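

In this assay the change gives a 7.8-fold lower number from compound 1 to compound 4 (0.89 log units; beyond the scatter) and is beyond the scatter, so the ((4-chlorophenyl)carbamoyl)amino unit is not needed at this amide-type nitrogen for the inhibition seen in this series, and 4-(trifluoromethyl)phenyl placed directly there gives the stronger inhibition. Within the data shown here, compound 4 also supplies the first pair that isolates the carbamoyl-amino linkage with the aromatic ring held constant: compound 2 reads 18000 nM against compound 4 at 7400 nM, and it supplies the pair that isolates the second trifluoromethyl group, with compound 3 at 3500 nM on the same read-out. No measurement on hand gives a cause for any of these differences.

The chloro-to-trifluoromethyl comparison remains tied to the longer linkage, so a 4-chlorophenyl group directly on the amide-type nitrogen would show whether that substituent swap reads the same way in the shorter series. All values also remain in one cell read-out with only halogen-bearing aromatic groups, which leaves open how a carboxylic acid, an amine or a methoxy group on that ring would behave.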